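The compounds below may be only part of what the source reports. "The series", "measured", "known", "first", "only" and "open" are said of these compounds alone.

Measured so far in a physicochemical assay for lipophilicity, using the shake flask method, measured as octanol-water partition; a higher number here means a more lipophilic compound, a lower number a more polar compound:
compound 1 `Cc1ccc2c(c1)c(=O)c(C(=O)O)cn2CC(O)Cn1c([N+](=O)[O-])cnc1C` gives -0.03
compound 2 `Cc1ncc([N+](=O)[O-])n1CC(O)Cn1cc(C(=O)O)c(=O)c2cccc(F)c21` gives -0.13

Compound 1 holds the higher of the two numbers, with compound 2 the nearest, but the gap between them lies within the scatter, so no order between the two can be read from these values. For the measured compounds named here, no pair of measured compounds that differ in one place is available, so no measured step exists to lean on.

Compound 3 `COc1ccc2c(c1)c(=O)c(C(=O)O)cn2CC(O)Cn1c([N+](=O)[O-])cnc1C` has not yet been run in this assay. It differs from compound 1 in one place: methoxy in place of methyl on an aromatic carbon. Going by the values given here, no measured pair covers this exchange, so the expectation rests on the structural change alone. The exchange of methyl for methoxy on the aromatic carbon is expected to lower the partition coefficient by a modest amount, somewhat beyond the scatter but not large. The estimate for compound 3 in this assay is -0.5, with a range from -0.9 to -0.1. That estimate corresponds to an expected step of a number 0.47 log units lower from compound 1 to compound 3 (beyond the scatter) in this assay.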

Compound 3, partition coefficient: -0.24
Compound 3: the middle estimate sits 0.26 log units below what was measured, and the stated range covers the measured number.
By their numbers in this assay, from the lowest: compounds 3, 2 and 1 (each within the scatter of the next).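

In this assay, for the compounds shown here, methoxy in place of methyl on an aromatic carbon, meta to a fused ring and para to a fused ring, gives the only single-place step available (a number 0.21 log units lower from compound 1 to compound 3 (within the scatter)) and so provides a first direct reading at this position. On this read-out, the exchange, which adds one heavy atom and one hydrogen-bond acceptor, does not separate compound 1 from compound 3, so no order can be assigned to the two compounds. The data shown offer no measured basis for explaining this result, and the step stands as an observation only.

Still open, going by these compounds, is how this position responds to groups of other kinds, such as an amine, a carboxylic acid or a longer alkoxy chain, and whether any of these would give a step beyond the scatter. It is also an open question whether the exchange of methyl for methoxy would read the same on another aromatic carbon of the shared core.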